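The compounds below may be only part of what the source reports. "The series", "measured", "known", "first", "only" and "open" are said of these compounds alone.

Measured in a functional assay on K562 cells (Homo sapiens) for antiproliferative activity, read by MTT assay, with a stated time of 48 h; on this read-out lower numbers stand for stronger inhibition and higher numbers for weaker inhibition:
- compound 1 `COC(=O)[C@H](C)NC(=O)c1ccc(Oc2nc3ccccc3nc2C)cc1`: 45500 nM
- compound 2 `CCCCCCCCCCCCNc1nc2ccccc2nc1Oc1ccc(C(=O)N[C@@H](C)C(=O)OC)cc1`: 26700 nM
- compound 3 `COC(=O)CNC(=O)c1ccc(Oc2nc3ccccc3nc2NC(C)(C)C)cc1`: > 50000 nM

Compound 3 sits at the limit of > 50000 nM in this assay, at which 1 of the 3 values shown sits; its entry is a limit and not a number.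

Compound 4 `CC[C@@H](C)[C@H](NC(=O)c1ccc(Oc2nc3ccccc3nc2NC(C)(C)C)cc1)C(=O)OC` departs from compound 3 by one change: sec-butyl in place of hydrogen on a saturated chain carbon bound to an amide-type nitrogen and a carbonyl carbon. This places sec-butyl in place of hydrogen on a saturated chain carbon bound to an amide-type nitrogen and a carbonyl carbon.

Going by the values given here, no measured pair isolates this change. Compound 1 at 45500 nM and compound 2 at 26700 nM lie within the usual scatter of each other, so only a small move is expected in this assay, not clearly beyond that scatter. The expected change is an at least 1.2-fold lower number from compound 3 to compound 4 (0.09 log units; that floor lies within the scatter). Compound 4 is estimated at 40000 nM, with an expected range of 15000 nM to 70000 nM.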

Compound 4, half-maximal inhibitory concentration: 38700 nM
Estimate against measurement, compound 4: 1.0-fold (0.01 log units) above; low and high end bracket the measured number.
By their numbers in this assay, from the lowest: compounds 2, 4 and 1 (each within the scatter of the next). At a limit, above all of these: compound 3.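

In this assay, going by these compounds alone, sec-butyl in place of hydrogen on the saturated chain carbon bound to an amide-type nitrogen and a carbonyl carbon gives the first readable step at this position: an at least 1.2-fold lower number from compound 3 to compound 4 (0.11 log units; that floor lies within the scatter). With sec-butyl on that carbon, compound 4 gives a number, 38700 nM, so the change is tolerated in this series. Compound 3 is held only as a limit: the limit of > 50000 nM in this assay, at which 1 of the 4 values shown sits.

From the compounds shown here alone, the full size of the step remains open. So does the outcome with a benzyl group, or a chain ending in an amine or a carboxylic acid, on that carbon.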